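Moving the methyl on the sulfonyl aryl ring

The source may report more compounds than this note shows. Statements on the series, on what has been measured and on what is new or still open speak of the compounds shown alone.

In a functional assay (Cavia porcellus) with sulfonylurea receptors; K-ATP channels (Homo sapiens) as the target (a lower number here means a stronger inhibitor, a higher number a weaker inhibitor), compound 3 `Cc1cccc(S(=O)(=O)c2ccc(NC(=O)C(C)(O)C(F)(F)F)cc2)c1` gives 2200 nM, the lowest of the two numbers shown. Compound 2 `CC(O)(C(=O)Nc1ccc(S(=O)(=O)c2ccccc2O)cc1)C(F)(F)F` gives 3090 nM, and the difference a 1.4-fold lower number from compound 2 to compound 3 (0.15 log units; within the scatter) lies within the scatter. Compound 1 `CC(O)(C(=O)Nc1ccc(S(=O)(=O)c2ccc(C#N)cc2)cc1)C(F)(F)F` reaches only a limit of this assay, > 30000 nM. The steps of an at least 9.7-fold lower number from compound 1 to compound 2 (0.98 log units; beyond the scatter) and an at least 13-fold lower number from compound 1 to compound 3 (1.13 log units; beyond the scatter) show that exchanging the 4-cyanophenyl lowers the number. Compound 4 `Cc1ccc(S(=O)(=O)c2ccc(NC(=O)C(C)(O)C(F)(F)F)cc2)cc1` differs from compound 3 by 4-methylphenyl in place of 3-methylphenyl on a sulfonyl sulfur. Among the compounds with values here, no measured step exchanges one methylphenyl for another; the nearest comparison, the change from compound 2 to compound 3, stayed within the scatter. For compound 4 a step of a 1.4-fold higher number from compound 3 to compound 4 (0.13 log units; within the scatter) is therefore expected, not clearly beyond the scatter. Compound 4 is estimated at 3000 nM, in a range from 1000 nM to 15000 nM.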

Compound 4, half-maximal inhibitory concentration: > 30000 nM
Compound 4 was reported as a limit (the forecaster's own chance of this, stated with the estimate: 12%); middle value at least 10-fold (1.00 log units) away from the limit.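

In this assay, the methyl's place on the ring alone separates two compounds of identical atoms, with an at least 13-fold higher number from compound 3 to compound 4 (1.13 log units; beyond the scatter), and the 2-hydroxyphenyl compound also differs clearly, with an at least 9.7-fold higher number from compound 2 to compound 4 (0.98 log units; beyond the scatter). Among these compounds, the 4-cyanophenyl and 4-methylphenyl groups both go with a limit, whereas the 3-methylphenyl and 2-hydroxyphenyl groups give numbers. Compound 4 stands at a limit, not a number, and its step from compound 1 cannot be read: the limit of > 30000 nM in this assay, at which 2 of the 4 values shown sit.

As far as these compounds go, whether an amine or a carboxylic acid in place of the methyl of compound 4 would also stay at that limit remains open.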